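The compounds below may be only part of what the source reports. "The series", "measured", "known", "first", "only" and "open" are said of these compounds alone.

Compound 1, `O=C(/C(=C\c1ccc(Br)c(O)c1)S(=O)(=O)c1ccc(Br)cc1)c1ccc(Br)cc1`, gives 50000 nM in a functional assay on DU-145 cells (Homo sapiens) for inhibition, read by trypan blue exclusion, with a stated time of 96 h; on this read-out lower numbers stand for stronger inhibition of growth and higher numbers for weaker inhibition of growth.
Compound 2, `COc1ccc(S/C(=C/c2ccc(Cl)cc2Cl)C(=O)c2ccc(Br)cc2)cc1`, gives 1000 nM in this assay.

Of these two measured numbers, compound 1 has the higher one, which on this read-out stands for the weaker inhibition of growth. The nearest and only other number is that of compound 2, which lies lower by a gap beyond the usual scatter of repeated measurements, so the two compounds are clearly told apart. Compound 2 differs from compound 1 in several places at once, so that gap cannot be tied to any single change.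

The next compound, compound 3, `COc1ccc(/C=C(\C(=O)c2ccc(Br)cc2)S(=O)(=O)c2ccc(Br)cc2)c(OC)c1`, has not yet been measured. It differs from compound 1 in one place: 2,4-dimethoxyphenyl in place of 4-bromo-3-hydroxyphenyl on a double-bonded chain carbon bound to a double-bonded chain carbon. The rest of the shared core of compound 1 is kept. For the measured compounds named here, no measured pair differs in only this one place, so the size of the effect can only be guessed. For compound 3 the expected step is a 5.0-fold lower number from compound 1 to compound 3 (0.70 log units; beyond the scatter) in this assay, toward stronger inhibition of growth, though a step that stays within the scatter would not be surprising. For compound 3 the estimate in this assay is 10000 nM, with a likely range from 2000 nM to 50000 nM.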

Compound 3, concentration for 50% growth inhibition: 8000 nM
For compound 3 the middle estimate is 1.3-fold (0.10 log units) above the measured one, and the stated range covers the measured number.
By their numbers in this assay, from the lowest: compound 2; then compound 3; then compound 1.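

Exchanging 4-bromo-3-hydroxyphenyl for 2,4-dimethoxyphenyl on a double-bonded chain carbon bound to a double-bonded chain carbon gives a 6.3-fold lower number from compound 1 to compound 3 (0.80 log units; beyond the scatter) in this assay and so shows that this position responds to what sits on it, with the rest of the shared core held fixed. The step is modest and runs toward stronger inhibition of growth, yet it comes from one exchange in which several things move at once: the bromine and the hydroxyl leave and the methoxy groups enter, so the step belongs to the whole swap and cannot be assigned to any one of these parts. Nothing in the data at hand explains why the number moves this way.

Still open, as far as these compounds go, is which of these parts matters: the loss of the bromine, the loss of the hydroxyl, or the arrival of either methoxy group. From the compounds shown here alone, how this position would respond to a phenyl ring carrying a single methoxy group, or to a ring bearing an amine or a carboxylic acid, also remains unknown.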